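A few compounds are considered here, and "the series" means these few. Any claim that something is new, unique, unknown or untested is made for them only; others in the source may bear on it.

Working notes on the series. For the measured compounds named here, compound 2 `O=C(O)CCCCCCCOc1ccc2c(=O)c(-c3ccc(O)cc3)coc2c1` is the only member with a number in an assay (Cricetulus griseus) for inhibition of Monoamine oxidase (Homo sapiens); on this read-out lower numbers stand for stronger inhibition and higher numbers for weaker inhibition: compound 2 gives 6500 nM. Compound 1 `O=c1c(-c2ccc(O)cc2)coc2cc(OCCCCCCCCCO)ccc12` returns only a limit in this assay, > 9000 nM, so that (the limit of > 9000 nM in this assay, at which 1 of the 2 values shown sits). Going by the values given here, the one measured step, an at least 1.3-fold lower number from compound 1 to compound 2 (0.14 log units; that floor lies within the scatter), therefore gives only a floor and its size stays within the scatter.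

Compound 3 `NCCCCOc1ccc2c(=O)c(-c3ccc(O)cc3)coc2c1` differs from compound 2 by amino in place of 3-carboxypropyl on a saturated chain carbon, four bonds along the chain from an oxygen on an aromatic ring. Among the compounds with values here, no measured step bears directly on this change: the step from compound 1 to compound 2 swaps the end of the chain but keeps its length, while here the chain is shortened and the carboxy is lost for an amino group. With nothing beyond the scatter in the measured step, no change beyond the scatter is expected, and the estimated step of a 1.1-fold lower number from compound 2 to compound 3 (0.03 log units; within the scatter) is set close to flat. The estimate for compound 3 in this assay is 6000 nM, with a range from 2000 nM to 20000 nM.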

Compound 3, half-maximal inhibitory concentration: > 9000 nM
Compound 3 was reported as a limit (the forecaster's own chance of this, stated with the estimate: 35%); middle value at least 1.5-fold (0.17 log units) away from the limit.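

Amino in place of 3-carboxypropyl, on a saturated chain carbon four bonds along the chain from an oxygen on an aromatic ring, gives an at least 1.3-fold higher number from compound 2 to compound 3 (0.14 log units; that floor lies within the scatter), so this change is bounded on one side only and its floor does not establish a real loss. For the compounds shown here, compound 2 remains the only compound with a number in this assay, and the values of the series now gather at one limit: the limit of > 9000 nM in this assay, at which 2 of the 3 values shown sit. The step between compound 1 and compound 3 cannot be read, as both values are limits.

What the compounds shown leave open is whether chain length or the end group sets the step, as the carboxy and amino ends stand on chains of different length. A carboxylic acid on a chain as short as that of compound 3, or an amine on a chain as long as that of compound 2, would separate the two.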